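A few compounds are considered here, and "the series" means these few. Any claim that something is new, unique, unknown or untested is made for them only; others in the source may bear on it.

Among the measured compounds shown here, in a functional assay, read by Griess assay, with a stated time of 2.5 h (on this read-out lower numbers stand for stronger inhibition and higher numbers for weaker inhibition), three compounds have numbers so far. Compound 1 `COc1cc(OC)c(-c2cc(=O)c3ccc(O)cc3o2)cc1OC` gives 2.27 ug/mL and compound 2 `COc1cc(OC)c(OC)cc1/C=C/C(=O)c1cc(Cc2ccccc2)cc(Cc2ccccc2)c1` gives 2.09 ug/mL while compound 3 `COc1cc(OC)c(OC)cc1/C=C/C(=O)c1ccc(O)cc1O` gives 2.76 ug/mL and these three numbers lie within the usual scatter of one another, so compound 3 stands level with the other two. Compound 4 `COc1cc(OC)c(OC)cc1/C=C/C(=O)c1ccc(F)cc1` is still unmeasured. Compared with compound 3 it carries 4-fluorophenyl in place of 2,4-dihydroxyphenyl on a carbonyl carbon as its only change. For the measured compounds named here, no measured pair shows such a change alone. Compound 2 has no 2,4-dihydroxyphenyl and still gives 2.09 ug/mL so only a small shift is expected in this assay here. The expected step of a 1.1-fold lower number from compound 3 to compound 4 (0.04 log units; within the scatter) stays within the scatter and has no firm direction. For compound 4 the estimated value is 2.5 ug/mL with an expected range of 1 ug/mL to 6.5 ug/mL on this read-out.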

Compound 4, half-maximal inhibitory concentration: 1.96 ug/mL
Compound 4: middle estimate off by 1.3-fold (0.11 log units), on the high side; measured number inside the range.
By their numbers in this assay, from the lowest: compounds 4, 2, 1 and 3 (each within the scatter of the next).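

In this assay, among the compounds shown here, replacing the 2,4-dihydroxyphenyl group with 4-fluorophenyl gives a 1.4-fold lower number from compound 3 to compound 4 (0.15 log units; within the scatter), the first direct look at a single change at this position. The entering group has no hydrogen-bond donors or acceptors, yet the number stays within the scatter, so the two hydroxyl groups are not needed to hold this level of inhibition. No measurement shown here explains this result. One replacement cannot show how far this tolerance extends. An amine or a carboxylic acid at this position might behave differently.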